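This account rests on a few compounds, and the source may have more. Where it says the series, first, only, none or still open, it means among the compounds named here.

Measured compounds:
compound 1 `C#CCOc1cccc(/C=C/C(=O)Nc2cc(C(=O)c3cc(OC)c(OC)c(OC)c3)ccc2OC)c1` — 14000 nM
compound 2 `COc1cc(C(=O)c2cc(OC)c(OC)c(OC)c2)cc(NC(=O)/C=C/c2cc(OC)c(OC)c(OC)c2)c1OC` — 2500 nM
compound 3 `COc1ccc(/C=C/C(=O)Nc2cc(C(=O)c3cc(OC)c(OC)c(OC)c3)cc(OC)c2OC)cc1N` — 15800 nM

In a functional assay on HeLa cells (Homo sapiens) for cytotoxicity, read by MTT assay, with a stated time of 72 h (a lower number here means a stronger inhibitor, a higher number a weaker inhibitor), compound 3 gives the highest number of the three. Compound 1 sits nearest, within the scatter; compound 2 lies furthest, and the step of a 6.3-fold higher number from compound 2 to compound 3 (0.80 log units; beyond the scatter) is the only one in this set that goes beyond the scatter.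

Compound 4 `C#CCOc1cccc(/C=C/C(=O)Nc2cc(C(=O)c3cc(OC)c(OC)c(OC)c3)cc(OC)c2OC)c1` is not yet measured. It differs from compound 3 in one place: 3-(propargyloxy)phenyl in place of 3-amino-4-methoxyphenyl on a double-bonded chain carbon bound to a double-bonded chain carbon. The change touches the same position as the step from compound 2 to compound 3, where replacing the 3,4,5-trimethoxyphenyl by the 3-amino-4-methoxyphenyl raised the number by a modest amount. Among the compounds with values here, no step in the set joins the 3-amino-4-methoxyphenyl and the 3-(propargyloxy)phenyl directly. What can be said is that compound 1, which carries the 3-(propargyloxy)phenyl on a different core, gives a number within the scatter of compound 3. On that basis no step beyond the scatter is expected for compound 4 in this assay; the expected step of a 1.3-fold lower number from compound 3 to compound 4 (0.12 log units; within the scatter) is small and without a firm direction. Compound 4 is therefore estimated at 12000 nM, with a range from 5000 nM to 30000 nM.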

Compound 4, half-maximal inhibitory concentration: 7300 nM
Estimate against measurement, compound 4: 1.6-fold (0.22 log units) above; low and high end bracket the measured number.
By their numbers in this assay, from the lowest: compound 2; then compounds 4, 1 and 3 (each within the scatter of the next, the first and the last beyond it).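

In this assay, the 3-(propargyloxy)phenyl on a double-bonded chain carbon bound to a double-bonded chain carbon can now be compared directly on the shared core with both other groups at this place: the 3-amino-4-methoxyphenyl (a 2.2-fold lower number from compound 3 to compound 4 (0.34 log units; beyond the scatter)) and the 3,4,5-trimethoxyphenyl (a 2.9-fold higher number from compound 2 to compound 4 (0.47 log units; beyond the scatter)). Together with the earlier step (a 6.3-fold higher number from compound 2 to compound 3 (0.80 log units; beyond the scatter)), this puts the three groups in an order on this core, with each pair separated beyond the scatter: 3,4,5-trimethoxyphenyl gives the lowest number, 3-(propargyloxy)phenyl the middle one and 3-amino-4-methoxyphenyl the highest. With 3-(propargyloxy)phenyl held constant, methoxy in place of hydrogen on an aromatic carbon stays within the scatter (a 1.9-fold lower number from compound 1 to compound 4 (0.28 log units; within the scatter)), so this pair shows no readable effect of that change.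

Open, from the compounds shown here alone, is where a phenyl bearing a hydroxy group or a carboxylic acid, or a longer alkyne chain in place of the propargyl chain, would fall in this order on the shared core. Nothing available here gives a reason for the order of the three groups.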